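A few compounds are considered here, and "the series" means these few. Any claim that something is new, unique, unknown or untested is made for them only; others in the source may bear on it.

Measured so far:
compound 1 `COc1ccccc1-n1nc(C2CC(C)(C)OC(C)(C)C2)cc1-c1ccc(Cl)cc1`: 96%
compound 2 `COc1ccccc1-n1nc(C2=CC(C)(C)OC(C)(C)C2)cc1-c1ccc(Cl)cc1`: 37%

In an ADME assay on microsomes from liver (Rattus norvegicus) for metabolic stability, with a stated time of 10 min (on this read-out lower numbers stand for a less stable compound and higher numbers for a more stable compound), compound 1 gives the higher of the two numbers, and the step of a number 59 percentage points lower from compound 1 to compound 2 (beyond the scatter) shows how far a change at this group can move the read-out. Compound 3 `COc1ccccc1-n1nc([C@H]2C[C@@H](C)O[C@@H](C)C2)cc1-c1ccc(Cl)cc1` differs from compound 1 by 2,6-dimethyloxan-4-yl in place of 2,2,6,6-tetramethyloxan-4-yl on an aromatic carbon. Going by the values given here, no measured step covers this exact change, so the expectation rests on compound 1 alone, with the size of a number 59 percentage points lower from compound 1 to compound 2 (beyond the scatter) as a guide to the possible spread. For compound 3 a moderate downward step a number 26 percentage points lower from compound 1 to compound 3 (beyond the scatter) is expected, giving an estimated 70% within 40% to 95%.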

Compound 3, percent of the compound remaining: 18%
Compound 3: middle estimate off by 52 percentage points, on the high side; measured number below the stated range.
By their numbers in this assay, from the lowest: compound 3; then compound 2; then compound 1.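

In this assay, the six-membered non-aromatic ring of the earlier pair changed at a ring bond, whereas here it changes only in its methyl substitution: 2,6-dimethyloxan-4-yl in place of 2,2,6,6-tetramethyloxan-4-yl gives a number 78 percentage points lower from compound 1 to compound 3 (beyond the scatter). Going by these compounds alone, the read-out at this position therefore responds to the methyl substitution alone, and the lowest number so far comes with a number 19 percentage points lower from compound 2 to compound 3 (beyond the scatter). Nothing available explains this drop. From the compounds shown here alone, whether the three defined stereocentres of compound 3 contribute remains open. So does how an amine or a longer chain would read at this position.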